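The source may hold more compounds than are shown below. What is called first, only, known or untested is meant among the compounds shown, and "the series" means these compounds.

Measured compounds and their values:

- Compound 1 `COc1cc2[nH]c(C)c(-c3ccc(Oc4ccc(OC(F)(F)F)c(F)c4)cc3)c(=O)c2cc1Cl`: in an ADME assay on HepG2 cells (Homo sapiens) for cytotoxicity, read by resazurin assay, with a stated time of 24 h (on this read-out lower numbers stand for stronger inhibition and higher numbers for weaker inhibition), compound 1 gives > 10000 nM, a limit of the assay rather than a number.
- Compound 2 `COc1cc2[nH]c(C)c(-c3ccc(Oc4cccc(OC(F)(F)F)c4)cc3)c(=O)c2cc1Cl`: in this assay compound 2 gives > 10000 nM, again a limit rather than a number.
- Compound 3 `Cc1[nH]c2ccc(Cl)cc2c(=O)c1-c1ccc(Oc2ccc(OC(F)(F)F)cc2)cc1`: in this assay compound 3 gives > 10000 nM, once more a limit rather than a number.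

Compound 2 therefore cannot be placed above or below its companions: every value shown sits at the same limit (the limit of > 10000 nM in this assay, at which 3 of the 3 values shown sit), so the three compounds are indistinguishable on these numbers, and none of them shows measurable cytotoxicity within the range this assay covers.

Compound 4 `COc1cc2[nH]c(C)c(-c3ccc(Oc4ccc(F)cc4)cc3)c(=O)c2cc1Cl` is the compound still to be measured. It differs from compound 2 in one place: 4-fluorophenyl in place of 3-(trifluoromethoxy)phenyl on an oxygen on an aromatic ring

Within the data shown here, no step between two measured compounds is available to guide the expectation, so the expectation rests on the three limits alone. Given that compound 2 and its two companions all reach the limit (the limit of > 10000 nM in this assay, at which 3 of the 3 values shown sit), the step from compound 2 to compound 4 in this assay is expected to be none beyond the usual scatter, and most likely compound 4 will also be reported only as a limit.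

The value of compound 4 in this assay is estimated at 20000 nM, with an expected range from 8000 nM to 100000 nM. The implied step that the limit leaves unreadable from compound 2 to compound 4 is expected to be no real change.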

Compound 4, half-maximal inhibitory concentration: > 10000 nM
Compound 4 gave a limit, no number (the forecaster's own chance of this, stated with the estimate: 85%); the middle value is on the limit's open side.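

In this assay compound 4 gives > 10000 nM, a limit of the assay rather than a number. The step from compound 2 to compound 4 cannot be read, because both compounds stop at the same limit: the limit of > 10000 nM in this assay, at which 4 of the 4 values shown sit. The compounds shown leave open whether 4-fluorophenyl in place of 3-(trifluoromethoxy)phenyl changes anything, and at what concentration, if any, these four compounds would register in this assay.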